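This account rests on a few compounds, and the source may have more. Where it says the series, first, only, none or still open, it means among the compounds named here.

Measured compounds:
compound 1 `CC(C)C1Cc2cc(OCc3ccc(-c4nn[nH]n4)cc3)c(Cl)c(Cl)c2C1=O`, 195 nM;
compound 2 `CC1(C)Cc2cc(OCc3ccc(-c4nn[nH]n4)cc3)c(Cl)c(Cl)c2C1=O`, 782 nM;
compound 3 `O=C1c2c(cc(OCc3cccc(CSc4ccncc4)c3)c(Cl)c2Cl)CC1C1CCCC1`, 165 nM.

In an assay on isolated protein for binding affinity to metabotropic glutamate receptor 2 (Homo sapiens) (on this read-out higher numbers stand for an effect only at larger amounts of compound and lower numbers for an effect already at smaller amounts), compound 3 gives the lowest number of the three. Compound 1 sits within the scatter of it, so no order between them can be read, whereas compound 2 lies beyond the scatter and shows a clearly higher number. Compound 4 `CCCC1Cc2cc(OCc3cccc(CSc4ccncc4)c3)c(Cl)c(Cl)c2C1=O` differs from compound 3 in one place: propyl in place of cyclopentyl on a saturated ring carbon. Among the compounds with values here, no measured pair in this set covers such a change, so the size of the step has to be guessed. Given the closeness of compound 1 and compound 3 across unrelated substituents, compound 4 is expected to show no step beyond the scatter, with at most a slight drift toward higher numbers, as in a 1.5-fold higher number from compound 3 to compound 4 (0.18 log units; within the scatter). The estimate for compound 4 in this assay is 250 nM, ranging from 100 nM to 650 nM.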

Compound 4, half-maximal effective concentration: 186 nM
The estimate for compound 4 lay 1.3-fold (0.13 log units) above the measured number; measured number inside the range.
By their numbers in this assay, from the lowest: compounds 3, 4 and 1 (each within the scatter of the next); then compound 2.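

In this assay, within the data shown here, propyl in place of cyclopentyl on a saturated ring carbon gives a 1.1-fold higher number from compound 3 to compound 4 (0.05 log units; within the scatter), the first comparison here that isolates a single change. At this position, with the rest of compound 3 held fixed, the open chain and the carbon ring therefore cannot be told apart. No measurement at hand bears on why this is so. On these data alone, what stays open is whether a longer chain such as hexyl would read the same at this carbon. Equally open, as far as these compounds go, is whether an amine or a carboxylic acid on the propyl chain would do so.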